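Benzylamine sulfonamides against pancreatic cell growth: working notes

A few compounds are considered here, and "the series" means these few. Any claim that something is new, unique, unknown or untested is made for them only; others in the source may bear on it.

Measured so far in a functional assay on MIA PaCa-2 cells (Homo sapiens) for inhibition, read by MTT assay, with a stated time of 72 h; on this read-out higher numbers stand for weaker inhibition of growth and lower numbers for stronger inhibition of growth:
compound 1 `O=S(=O)(NCCCNCc1ccc(Cl)c(Cl)c1)c1cc(C(F)(F)F)cc(C(F)(F)F)c1`: 2700 nM
compound 2 `CCCCc1ccc(S(=O)(=O)NCCCCCCNCc2ccc(Br)cc2)cc1`: 5700 nM

Compound 1 has the lowest number of the two, and compound 2 stands above it by a step beyond the usual scatter. The two differ in more than one place, so no single change is isolated by this pair.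

Compound 3 `COc1cccc(CNCCCNS(=O)(=O)c2cc(C(F)(F)F)cc(C(F)(F)F)c2)c1` keeps the core of compound 1 and differs from it in one place: 3-methoxyphenyl in place of 3,4-dichlorophenyl on a saturated chain carbon bound to an amine nitrogen. Going by the values given here, no measured pair shows this change, so nothing in the data fixes its size or direction in this assay. A somewhat higher number than that of compound 1 is expected for compound 3, with a 1.9-fold higher number from compound 1 to compound 3 (0.27 log units; within the scatter) as the expected step, a modest shift only a little beyond the scatter. With no anchor for the change, a wide range is kept. Compound 3 is estimated at 5000 nM, within 1500 nM to 15000 nM.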

Compound 3, concentration for 50% growth inhibition: 3400 nM
For compound 3 the middle estimate is 1.5-fold (0.17 log units) above the measured one; low and high end bracket the measured number.
By their numbers in this assay, from the lowest: compounds 1, 3 and 2 (each within the scatter of the next, the first and the last beyond it).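

In this assay, going by these compounds alone, 3-methoxyphenyl in place of 3,4-dichlorophenyl on a saturated chain carbon bound to an amine nitrogen gives the first step that isolates a single change (a 1.3-fold higher number from compound 1 to compound 3 (0.10 log units; within the scatter)). Compound 1 and compound 3 cannot be told apart on this read-out, so at this position the two chlorine atoms can give way to a methoxy-bearing ring with no change beyond the scatter. No measurement on hand accounts for this result.

Going by these compounds, whether a carboxylic acid, a dimethylamino group or a pyridine ring in place of the 3-methoxyphenyl would move the number beyond the scatter remains open. Compound 2 still differs from compound 1 and compound 3 in more than one place, so the contributions of its chain and its other groups remain unseparated.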